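A few compounds are considered here, and "the series" means these few. Any claim that something is new, unique, unknown or untested is made for them only; others in the source may bear on it.

Compound 2 `COc1ccc(/C=C/C(=O)c2ccc(N3CCN(c4ccc(Cl)c(Cl)c4)CC3)cc2)cc1OC` stands highest of the three compounds measured in a functional assay on the whole organism (strain Kunming) for inhibition, with Mus musculus as the target, with a stated time of 1 h, at a dose of 40 mg/kg by the oral route; on this read-out higher numbers stand for more inhibition at the one dose given (going by the name of the read-out) and lower numbers for less inhibition. In this assay compound 2 gives 63.5%. Its nearest neighbour, compound 3 `O=C(/C=C/c1ccccc1)c1ccc(N2CCN(S(=O)(=O)c3ccc4ccccc4c3)CC2)cc1`, gives 35%, and the furthest, compound 1 `O=C(/C=C/c1ccccc1)c1ccc(N2CCN(c3ccc(Cl)c(Cl)c3)CC2)cc1`, gives 13.4%. Compound 1 and compound 2 differ in one place, and the step of a number 50.1 percentage points higher from compound 1 to compound 2 (beyond the scatter). Compound 4 `COc1ccc(/C=C/C(=O)c2ccc(N3CCN(S(=O)(=O)c4ccc(Br)cc4)CC3)cc2)cc1OC` keeps that 3,4-dimethoxyphenyl, so this step does not bear directly on the move to compound 4. Compound 4 differs from compound 2 by (4-bromophenyl)sulfonyl in place of 3,4-dichlorophenyl on an amine nitrogen in a ring. Among the compounds with values here, no measured step covers a change of this kind. Within the data shown here, the only hint comes from compound 1 and compound 3, which differ at the same ring nitrogen: compound 3 gives the higher number there, though its group is not the (4-bromophenyl)sulfonyl entering in compound 4. For compound 4 the estimated value in this assay is 66%, with a range from 42% to 85%. This means an expected step of a number 2.5 percentage points higher from compound 2 to compound 4 (within the scatter) that stays within the scatter.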

Compound 4, a percentage reported as inhibition, in the whole organism at one dose (the size of the read-out at that dose, not a potency): 75.5%
Compound 4: middle estimate off by 9.5 percentage points, on the low side, within the range that was stated.
By their numbers in this assay, from the lowest: compound 1; then compound 3; then compound 2; then compound 4.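

Placing (4-bromophenyl)sulfonyl in place of 3,4-dichlorophenyl on the ring nitrogen gives, in this assay, a number 12 percentage points higher from compound 2 to compound 4 (beyond the scatter), so with the 3,4-dimethoxyphenyl kept, this nitrogen can carry a sulfonyl-linked aryl group and the number still rises. The entering group has 10 heavy atoms and 2 hydrogen-bond acceptors where the leaving group has 8 and 0, and it also swaps two chlorine atoms for a bromine, so several things change in this one step. Nothing measured here explains the rise.

The compounds shown do not separate the part played by the sulfonyl link from that of the bromine, which a plain phenylsulfonyl or a methylsulfonyl group at this nitrogen would help to tell apart. They also leave open whether an amide link at this nitrogen, such as a benzoyl group, would serve as well.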